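Phenyl to 3-fluorophenyl on compound 2

The source may hold more compounds than are shown below. What is called first, only, known or untested is meant among the compounds shown, and "the series" means these compounds.

Measured so far in a physicochemical assay for lipophilicity; a higher number here means a more lipophilic compound, a lower number a more polar compound:
- compound 1 `Cc1ccccc1C1C[C@@]2(ON1c1ccccc1)C(=O)O[C@@H]1[C@H]2CC[C@H](C)[C@]2(O)C=CC(=O)[C@@]12C` at 3.64
- compound 2 `C[C@H]1CC[C@@H]2[C@@H](OC(=O)[C@]23CC(c2ccccc2)N(c2ccccc2)O3)[C@]2(C)C(=O)C=C[C@@]12O` at 3.19

Compound 2 holds the lower of the two numbers. Among the measured compounds shown here, its gap to compound 1 is the only measured step: a number 0.45 log units lower from compound 1 to compound 2 (beyond the scatter) with hydrogen in place of methyl on an aromatic carbon.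

The next compound is compound 3 `C[C@H]1CC[C@@H]2[C@@H](OC(=O)[C@]23CC(c2cccc(F)c2)N(c2ccccc2)O3)[C@]2(C)C(=O)C=C[C@@]12O` and its difference is fluoro in place of hydrogen on an aromatic carbon with fluoro in place of hydrogen on an aromatic carbon, meta to a large group. For the measured compounds named here, no fluoro compound has been measured, so the size of this step cannot be read directly from the data. Going by the values given here, the one step that bears on it is a number 0.45 log units lower from compound 1 to compound 2 (beyond the scatter) and that also concerns a group exchanged for hydrogen on an aromatic carbon. Judged against that step, a small upward move is expected, smaller than the one seen for methyl. The expected step is a number 0.16 log units higher from compound 2 to compound 3 (within the scatter) and it may not stand clear of the scatter. Compound 3 is estimated at 3.35 with an expected range from 3.1 to 3.65 as its bounds.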

Compound 3, partition coefficient: 3.35
The estimate for compound 3 equals the measured number at the digits printed; measured number inside the range.
By their numbers in this assay, from the lowest: compounds 2, 3 and 1 (each within the scatter of the next, the first and the last beyond it).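

In this assay, the first fluoro compound gives a number 0.16 log units higher from compound 2 to compound 3 (within the scatter) as its step, so at this place, on an aromatic carbon meta to a large group, fluoro in place of hydrogen cannot be told apart from hydrogen. The exchange of 2-methylphenyl for 3-fluorophenyl on the same saturated ring carbon gives a number 0.29 log units lower from compound 1 to compound 3 (within the scatter) as its step, so compound 3 cannot be separated from compound 1 or from compound 2, even though a number 0.45 log units lower from compound 1 to compound 2 (beyond the scatter) is a step that does separate those two. Among the compounds shown here, nothing measured so far offers a reason for the size of these steps.

Still open, from the compounds shown here alone, is whether a trifluoromethyl group, a methoxy group or an amine on this phenyl ring would give a step that stands clear of the scatter in this assay as a read-out. With only 2-methylphenyl and 3-fluorophenyl to compare, the identity of the group and its place on the ring remain tied together, and a pair such as 3-methylphenyl and 2-fluorophenyl would be needed to pull them apart.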